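The source may hold more compounds than are shown below. What is called first, only, known or untested is meant among the compounds shown, and "the series" means these compounds.

Of the compounds shown here, three have been measured in an in vitro functional assay on cells for agonist activity at Bombesin receptor subtype-3 (Mus musculus), read by luminescence and calcium flux (on this read-out lower numbers stand for an effect already at smaller amounts and higher numbers for an effect only at larger amounts of compound), and a fourth awaits measurement. Compound 1 `CCCCc1cnc(C(CCCO)Cc2ccc(-c3ccccc3C(=O)O)cc2)[nH]1` gives in this assay a value of 238 nM. Compound 2 `O=C(O)c1ccccc1-c1ccc(CCc2ncc(-c3ccccc3)[nH]2)cc1` gives 872 nM, while compound 3 `Cc1cccc(Cc2cnc(CCc3ccc(-c4ccccc4C(=O)O)cc3)[nH]2)c1` gives 75 nM. For the measured compounds named here, the single measured step between compounds differing in one place, 3-methylbenzyl in place of phenyl on an aromatic carbon, amounts to a 12-fold lower number from compound 2 to compound 3 (1.07 log units; beyond the scatter). Compound 1 therefore stands second highest of the three numbers, nearest to compound 3 and furthest from compound 2.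

Compound 4 `CCCCc1cnc(C(Cc2ccc(-c3ccccc3C(=O)O)cc2)C(C)C)[nH]1` differs from compound 1 in one place: isopropyl in place of 3-hydroxypropyl on a saturated chain carbon bound to an aromatic carbon and a saturated chain carbon. Going by the values given here, no measured step bears on this change; the only measured step alters a different part of the shared core, and no measured pair shows what exchanging the 3-hydroxypropyl does in this assay. With nothing to anchor a direction, the expected step is a 1.1-fold higher number from compound 1 to compound 4 (0.02 log units; within the scatter), that is, no change beyond the scatter, though a wider spread is allowed for in either direction. Compound 4 is accordingly estimated at 250 nM, with a range from 80 nM to 800 nM.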

Compound 4, half-maximal effective concentration: 2240 nM
Compound 4: the middle estimate sits 9.0-fold (0.95 log units) below what was measured; the measured number lies above the stated range.
By their numbers in this assay, from the lowest: compound 3; then compound 1; then compound 2; then compound 4.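

For the compounds shown here, the exchange at this saturated chain carbon is far from neutral: in this assay, isopropyl in place of 3-hydroxypropyl gives a 9.4-fold higher number from compound 1 to compound 4 (0.97 log units; beyond the scatter) and shows that this place, on which no earlier pair bore, can move the read-out on its own. The series now has a second place where a single exchange carries the number beyond the scatter, although the two steps start from different compounds and cannot be set against each other as a trend. Nothing available here explains the rise in the number.

The exchange alters two things at once, as the entering isopropyl differs from the leaving 3-hydroxypropyl both in its carbon skeleton and in lacking the hydroxyl, and this single pair does not tell which of the two matters. Going by these compounds, an unbranched propyl chain would separate those two changes, while a 3-aminopropyl chain or a carboxylic acid at the chain end would test whether another group can stand in for the hydroxyl, and it remains open whether the step would have the same size on other members.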